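The compounds below may be only part of what the source reports. "The series", "measured", "known", "first", "only" and "open" are said of these compounds alone.

The measured compounds:
Compound 1 `Clc1ccc(-c2cc(-c3ccsc3)nc(-c3ccccc3Cl)c2)o1` gives 8070 nM in a functional assay on HeLa cells (Homo sapiens) for cytotoxicity, in the presence of a further agent that is not named here; on this read-out lower numbers stand for stronger inhibition and higher numbers for weaker inhibition.
Compound 2 `Clc1ccc(-c2cc(-c3ccoc3)cc(-c3ccsc3)n2)cc1` gives 4140 nM in this assay.
Compound 3 `Clc1cccc(-c2cc(-c3ccc(Cl)o3)cc(-c3cccs3)n2)c1` gives 12800 nM in this assay.

Among these three, compound 1 carries the second highest number, yet its gap to compound 3, the nearest of the others, and its gap to compound 2, the furthest, both lie within the usual scatter of repeated measurements. The three compounds can therefore not be ranked against one another on this evidence; they sit together in the same region of this assay.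

Compound 4 `Clc1ccc(-c2cc(-c3ccsc3)nc(-c3ccccn3)c2)o1` has not yet been measured. It differs from compound 1 in one place: pyridin-2-yl in place of 2-chlorophenyl on an aromatic carbon. Within the data shown here, no pair of measured compounds shows a change of this kind, so nothing here tells how this assay responds to it. What is known is that the other aryl groups carried by compound 2 and compound 3 on the shared core leave the numbers within the scatter of compound 1. The step from compound 1 to compound 4 is accordingly expected to be small, with no clear direction beyond the scatter. For compound 4 in this assay the estimate is 8000 nM, within a range from 2500 nM to 25000 nM. That estimate corresponds to an expected step of a 1.0-fold lower number from compound 1 to compound 4 (0.00 log units; within the scatter).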

Compound 4, half-maximal inhibitory concentration: 22500 nM
Estimate against measurement, compound 4: 2.8-fold (0.45 log units) below, and the stated range covers the measured number.
By their numbers in this assay, from the lowest: compounds 2, 1, 3 and 4 (each within the scatter of the next, the first and the last beyond it).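

The position on the aromatic carbon next to the ring nitrogen is not indifferent to what it carries: in this assay, pyridin-2-yl in place of 2-chlorophenyl brings a 2.8-fold higher number from compound 1 to compound 4 (0.45 log units; beyond the scatter), the first single-place step available, and it points towards weaker inhibition. The exchange removes the chlorine and at the same time puts a ring nitrogen, counted as a hydrogen-bond acceptor, into the six-membered aromatic ring, so this one step cannot separate the two alterations. Nothing measured here accounts for the step.

Going by these compounds, how a plain phenyl or a 2-methoxyphenyl group would stand at this position remains open, and with it whether the step follows the chlorine or the ring nitrogen. Also open, on these data alone, is whether the same exchange would give a similar step with a morpholine in place of the thiophen-3-yl group.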